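A few compounds are considered here, and "the series" means these few. Any claim that something is new, unique, unknown or untested is made for them only; others in the source may bear on it.

Compound 1 `CC(C)c1ccc(-c2nc(SCc3cn(CC(=O)NC(=O)Nc4ccccn4)nn3)nc(Nc3ccccc3)c2C#N)cc1`: 14300 nM in a functional assay on B16-F10 cells (Mus musculus) for inhibition, read by MTT assay, with a stated time of 72 h; a lower number here means a stronger inhibitor, a higher number a weaker inhibitor. Compound 2 `CC(C)c1ccc(Nc2nc(SCc3cn(CC(=O)NC(=O)Nc4ccccn4)nn3)nc(-c3ccc(C(C)C)cc3)c2C#N)cc1`: 4380 nM. Compound 3 `COc1cc(-c2nc(SCc3cn(CC(=O)NC(=O)Nc4ccccn4)nn3)nc(Nc3ccc(C(C)C)cc3)c2C#N)cc(OC)c1OC`: 1210 nM.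

Compound 3 stands lowest of the three, with a 3.6-fold lower number from compound 2 to compound 3 (0.56 log units; beyond the scatter) and a wider gap to compound 1. Compound 4 `COc1cc(-c2nc(SCc3cn(CC(=O)NC(=O)Nc4ccccn4)nn3)nc(Nc3cccc(Cl)c3)c2C#N)cc(OC)c1OC` differs from compound 3 by 3-chlorophenyl in place of 4-isopropylphenyl on a nitrogen on an aromatic ring. Of the two measured steps, only a 3.3-fold lower number from compound 1 to compound 2 (0.51 log units; beyond the scatter) concerns the aryl on this nitrogen; the other step lies on the aryl carbon and says nothing about this position. Compound 4 gives up the isopropyl that earlier step added, and a 3-chlorophenyl of unknown effect enters. A modest weakening beyond the scatter is expected, a 2.6-fold higher number from compound 3 to compound 4 (0.42 log units; beyond the scatter). Compound 4 is therefore estimated at 3200 nM, between 1100 nM and 9500 nM.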

Compound 4, half-maximal inhibitory concentration: 1420 nM
Compound 4: the middle estimate sits 2.3-fold (0.35 log units) above what was measured, within the range that was stated.
By their numbers in this assay, from the lowest: compounds 3 and 4 (each within the scatter of the next); then compound 2; then compound 1.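

In this assay the exchange of 4-isopropylphenyl for 3-chlorophenyl on the nitrogen, with 3,4,5-trimethoxyphenyl held on the aromatic carbon, gives (a 1.2-fold higher number from compound 3 to compound 4 (0.07 log units; within the scatter)). The isopropyl, whose addition gave (a 3.3-fold lower number from compound 1 to compound 2 (0.51 log units; beyond the scatter)) with a 4-isopropylphenyl on that carbon, is thus not required at this position when 3,4,5-trimethoxyphenyl is present, since a chlorine-bearing aryl reads the same within the scatter. Nothing shown gives a reason for this result. Still open, on these data alone, is whether the chlorine's place on the ring counts, and how an aryl carrying an amine or a carboxylic acid would read here.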